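The source may hold more compounds than are shown below. What is called first, only, known or untested is meant among the compounds shown, and "the series" means these compounds.

Measured in a functional assay on MCF7 cells (Homo sapiens) for cytotoxicity, read by MTT assay, with a stated time of 72 h; on this read-out higher numbers stand for weaker inhibition and lower numbers for stronger inhibition:
- compound 1 `O=C1c2c[n+]([O-])c3ccccc3c2C(=O)c2c1c1ccccc1n2Cc1cn(C[C@H](O)CO)nn1`: > 1000 nM, a limit and not a number
- compound 2 `O=C1c2c[n+]([O-])c3ccccc3c2C(=O)c2c1c1ccccc1n2Cc1cn(CC(O)CO)nn1`: 1110 nM

For the measured compounds named here, compound 2 holds the only actual number so far. Going by the values given here, the one measured step, a step that the limit leaves unreadable from compound 1 to compound 2, has no readable size because of the limit of > 1000 nM in this assay, at which 1 of the 2 values shown sits. It concerns only (the fact that one of compounds 1 and 2 is drawn with a defined configuration and the other without, at the place where they differ), so it does not bear on the next change.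

Compound 3 `O=C1c2c[n+]([O-])c3ccccc3c2C(=O)c2c1c1ccccc1n2CCN1CCCC1` differs from compound 2 as follows: (pyrrolidin-1-yl)methyl in place of 1-(2,3-dihydroxypropyl)-1H-1,2,3-triazol-4-yl on a saturated chain carbon bound to an aromatic nitrogen. This places (pyrrolidin-1-yl)methyl in place of 1-(2,3-dihydroxypropyl)-1H-1,2,3-triazol-4-yl on a saturated chain carbon bound to an aromatic nitrogen. No measured step sizes this change, so the expectation is loosely held.

An estimated 2.2-fold lower number from compound 2 to compound 3 (0.35 log units; beyond the scatter) is expected in this assay, towards stronger inhibition. For compound 3 the estimate is 500 nM, with an expected range of 100 nM to 2500 nM.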

Compound 3, half-maximal inhibitory concentration: 320 nM
Beside the measured number, compound 3's estimate is 1.6-fold (0.19 log units) above it; low and high end bracket the measured number.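

In this assay, for the compounds shown here, (pyrrolidin-1-yl)methyl in place of 1-(2,3-dihydroxypropyl)-1H-1,2,3-triazol-4-yl on a saturated chain carbon bound to an aromatic nitrogen gives the first readable step at this position, a 3.5-fold lower number from compound 2 to compound 3 (0.54 log units; beyond the scatter). The same change read against the compound with the drawn configuration gives an at least 3.1-fold lower number from compound 1 to compound 3 (0.49 log units; beyond the scatter), which is only a bound: the limit of > 1000 nM in this assay, at which 1 of the 3 values shown sits. Nothing shown ties either step to a property of the groups.

From the compounds shown here alone, whether the step follows the pyrrolidine ring or the loss of the triazole remains open. Also open, going by these compounds, is how a 2-(dimethylamino)ethyl or 2-(piperidin-1-yl)ethyl group would read in place of 2-(pyrrolidin-1-yl)ethyl.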